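The source may hold more compounds than are shown below. What is called first, only, known or untested is meant among the compounds shown, and "the series" means these compounds.

In an ADME assay on the whole organism (strain FVB) for pharmacokinetics, with Mus musculus as the target, read by LC-MS, at a dose of 30 mg/kg by the oral route (a lower number here means less compound in the circulation, a higher number more compound in the circulation at the dose given), compound 1 (`CC(C)(O)CN1CCC(Oc2ccc([C@H]3CC[C@]4(CC3)OOC3(O4)C4CC5CC(C4)CC3C5)cc2)CC1`) gives 1810 nM, compound 2 (`c1cc([C@H]2CC[C@]3(CC2)OOC2(O3)C3CC4CC(C3)CC2C4)ccc1OCCC1CCNCC1`) gives 1190 nM and compound 3 (`c1cc([C@H]2CC[C@]3(CC2)OOC2(O3)C3CC4CC(C3)CC2C4)ccc1OC1CCNCC1`) gives 810 nM. Compound 2 is not separated from either of the others: a 1.5-fold lower number from compound 1 to compound 2 (0.18 log units; within the scatter) and a 1.5-fold lower number from compound 2 to compound 3 (0.17 log units; within the scatter) both stay within the scatter. Only a 2.2-fold lower number from compound 1 to compound 3 (0.35 log units; beyond the scatter) goes beyond it, and that step is modest.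

Compound 4 (`CC1(C)CC(O)(COc2ccc([C@H]3CC[C@]4(CC3)OOC3(O4)C4CC5CC(C4)CC3C5)cc2)CC(C)(C)N1`) differs from compound 2 as follows: 4-hydroxy-2,2,6,6-tetramethylpiperidin-4-yl in place of (piperidin-4-yl)methyl on a saturated chain carbon bound to an oxygen on an aromatic ring. The change lies on a saturated chain carbon bound to an oxygen on an aromatic ring. For the measured compounds named here, no measured step makes this exchange. The closest in kind are the two steps that alter the group on the oxygen, and neither of them left the scatter. The largest step seen among these compounds is the modest one from compound 1 to compound 3, so no step beyond the scatter is expected in this assay, in either direction. The expected step is a 1.1-fold higher number from compound 2 to compound 4 (0.04 log units; within the scatter). For compound 4 the maximal plasma concentration is estimated at 1300 nM, with an expected range of 550 nM to 3000 nM.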

Compound 4, maximal plasma concentration: 1000 nM
Beside the measured number, compound 4's estimate is 1.3-fold (0.11 log units) above it; the measured number falls inside the stated range.
By their numbers in this assay, from the lowest: compounds 3, 4, 2 and 1 (each within the scatter of the next, the first and the last beyond it).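

In this assay, the larger 4-hydroxy-2,2,6,6-tetramethylpiperidin-4-yl in place of (piperidin-4-yl)methyl on a saturated chain carbon bound to an oxygen on an aromatic ring gives a 1.2-fold lower number from compound 2 to compound 4 (0.08 log units; within the scatter) and so leaves the number unresolved from that of compound 2. Compound 4 is equally unresolved from the other two compounds, with a 1.2-fold higher number from compound 3 to compound 4 (0.09 log units; within the scatter) and a 1.8-fold lower number from compound 1 to compound 4 (0.26 log units; within the scatter) as its steps, so this group adds no new separation among the compounds shown. Nothing at hand accounts for how closely compound 4 sits to the others.

What the compounds leave open is whether a group without a ring amine, such as a carboxylic acid or an open-chain amine, would stay as close on an oxygen on an aromatic ring. As far as these compounds go, whether a longer chain there would do the same is also open.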